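The source may report more compounds than this note shows. Statements on the series, on what has been measured and on what is new or still open speak of the compounds shown alone.

Two compounds of this series have numbers in an assay on COS-1 cells for displacement of a labelled ligand from sodium-dependent dopamine transporter (Homo sapiens); a lower number here means a stronger inhibitor, a higher number a weaker inhibitor. Compound 1 `CCOC(=O)C1=C(c2ccc3ccccc3c2)CCNC1` gives 79 nM in this assay. Among the compounds with values here, compound 2 `COC(=O)C1=C(c2ccc(Cl)cc2)CCCCC1` gives 15000 nM in this assay, the higher of the two numbers and far from compound 1, well beyond the scatter; the two differ in more than one place, so no single step is drawn between them.

The next compound, compound 3 `COC(=O)C1=C(c2ccc(C(C)(C)C)cc2)CCCCC1`, keeps the core of compound 2 and carries one change: tert-butyl in place of chloro on an aromatic carbon. Within the data shown here, no measured pair shows what an exchange of this kind does in this assay, so the direction of the step cannot be read from the data at hand.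

The step from compound 2 to compound 3 is expected to be modest, a 1.7-fold higher number from compound 2 to compound 3 (0.22 log units; within the scatter), with a slightly higher number considered more likely than a lower one. For compound 3 the estimate in this assay is 25000 nM, with a range from 5000 nM to 100000 nM.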

Compound 3, inhibition constant: 884000 nM
For compound 3 the middle estimate is 35-fold (1.55 log units) below the measured one; the measured number lies above the stated range.
By their numbers in this assay, from the lowest: compound 1; then compound 2; then compound 3.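

In this assay, within the data shown here, the exchange of chloro for tert-butyl on an aromatic carbon, para to a large group, gives a 59-fold higher number from compound 2 to compound 3 (1.77 log units; beyond the scatter) and provides the first single-place step. This position is therefore not indifferent to its substituent: in this one pair, the move to a group of 4 heavy atoms from 1 heavy atom goes with a much weaker inhibitor, with no hydrogen-bond donor, acceptor or net charge entering or leaving. Nothing at hand bears on the reason for this loss.

Going by these compounds, it remains open whether a smaller group such as methyl or methoxy at this carbon would stay close to chloro or already lose binding. Also open, on these data alone, is whether the same exchange would carry over to the core of compound 1, and how an amine or a carboxylic acid would fare at this carbon.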